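Replacing the nitro group of compound 3 with hydrogen

A few compounds are considered here, and "the series" means these few. Any claim that something is new, unique, unknown or untested is made for them only; others in the source may bear on it.

In a functional assay on A549 cells (Homo sapiens) for antiproliferative activity, read by MTT assay, with a stated time of 48 h (on this read-out lower numbers stand for stronger inhibition and higher numbers for weaker inhibition), compound 1 (`Cc1ccc2nc(NC(c3cn(-c4ccccc4)nc3-c3cccc(Cl)c3)c3c(O)ccc4ccccc34)sc2c1`) gives 45400 nM, compound 2 (`Cc1cc2nc(NC(c3cn(-c4ccccc4)nc3-c3ccc([N+](=O)[O-])cc3)c3c(O)ccc4ccccc34)sc2cc1C`) gives 41900 nM, and compound 3 (`COc1ccc2nc(NC(c3cn(-c4ccccc4)nc3-c3ccc([N+](=O)[O-])cc3)c3c(O)ccc4ccccc34)sc2c1`) gives 22500 nM. Compound 3 therefore stands within the scatter of both others. Compound 4 (`COc1ccc2nc(NC(c3cn(-c4ccccc4)nc3-c3ccccc3)c3c(O)ccc4ccccc34)sc2c1`) differs from compound 3 by hydrogen in place of nitro on an aromatic carbon. Within the data shown here, the only measured step, a 1.9-fold lower number from compound 2 to compound 3 (0.27 log units; within the scatter), lies within the scatter and concerns another part of the molecule, so no measured pair tests this change directly. No step beyond the scatter is expected in this assay. The expected step is a 1.3-fold higher number from compound 3 to compound 4 (0.12 log units; within the scatter). For compound 4 the estimated value is 30000 nM, with an expected range from 12000 nM to 70000 nM.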

Compound 4, half-maximal inhibitory concentration: 44600 nM
Compound 4: middle estimate off by 1.5-fold (0.17 log units), on the low side; the range from low to high includes it.
By their numbers in this assay, from the lowest: compounds 3, 2, 4 and 1 (each within the scatter of the next).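

In this assay, hydrogen in place of nitro gives a 2.0-fold higher number from compound 3 to compound 4 (0.30 log units; within the scatter) as the first direct test of this position, para to a large group. At this place, then, nitro and hydrogen cannot be told apart, and the 4-nitrophenyl group is not shown to be needed for the activity of compound 3. No measurement shown explains this result. The compounds shown leave open whether an amine or a carboxylic acid at this position would give a value beyond the scatter of compound 3 and compound 4.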